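Moving from 2-chlorophenyl to 3,4-dichlorophenyl

The compounds below may be only part of what the source reports. "The series", "measured", "known", "first", "only" and "open" are said of these compounds alone.

Compound 1 `COc1cc(C(=O)c2sc(-c3ccncc3)cc2N)cc(OC)c1OC` gives 110 nM
Compound 2 `COc1cc(C(=O)c2sc(-c3ccccc3Cl)cc2N)cc(OC)c1OC` gives 16 nM

In a functional assay on CCRF-CEM cells (Homo sapiens) for antiproliferative activity (a higher number here means a weaker inhibitor, a lower number a stronger inhibitor), compound 2 holds the lower of the two numbers, at 16 nM so far. Compound 3 `COc1cc(C(=O)c2sc(-c3ccc(Cl)c(Cl)c3)cc2N)cc(OC)c1OC` differs from compound 2 in one group: 3,4-dichlorophenyl in place of 2-chlorophenyl on an aromatic carbon is the whole change. Within the data shown here, only one measured step bears on it, a 6.9-fold lower number from compound 1 to compound 2 (0.84 log units; beyond the scatter) and it is modest. That step involved a different pair of groups, so it suggests a size but no firm direction. A similar or smaller step toward a higher number is expected, and this estimate reads a 2.2-fold higher number from compound 2 to compound 3 (0.34 log units; beyond the scatter) in numbers. Compound 3 is estimated at 35 nM with an expected range from 7 nM to 170 nM for now.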

Compound 3, half-maximal inhibitory concentration: 290 nM
Compound 3: the middle estimate sits 8.3-fold (0.92 log units) below what was measured; measured number above the stated range.
By their numbers in this assay, from the lowest: compound 2; then compound 1; then compound 3.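

In this assay, the group at this position on the sulfur ring is far from interchangeable among chlorinated phenyls: 3,4-dichlorophenyl in place of 2-chlorophenyl gives an 18-fold higher number from compound 2 to compound 3 (1.26 log units; beyond the scatter), a large step. The same group in place of pyridin-4-yl gives a 2.6-fold higher number from compound 1 to compound 3 (0.42 log units; beyond the scatter), so a chlorinated phenyl does not always beat pyridin-4-yl here. Nothing available explains this loss. This single change both moves and adds chlorine, and the two effects cannot be separated. As far as these compounds go, how an unsubstituted phenyl or a methoxyphenyl would behave at this position remains open.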